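Extending the Hydroxymethyl Group into a Formyl-Bearing Phenoxy

A few compounds are considered here, and "the series" means these few. Any claim that something is new, unique, unknown or untested is made for them only; others in the source may bear on it.

Compound 3 `COc1cc2c(cc1OC)CN(S(=O)(=O)c1ccc(-n3cc(CO)nn3)cc1)CC2` was tested in an ADME assay on Vero cells (Chlorocebus sabaeus) for cytotoxicity, with a stated time of 4 days; on this read-out higher numbers stand for weaker inhibition and lower numbers for stronger inhibition. In this assay compound 3 gives > 50 ug/mL, which is a limit of the assay rather than a number. Compound 1 `COc1cc2c(cc1OC)CN(S(=O)(=O)c1ccc(-n3cc(COc4ccccc4)nn3)cc1)CC2` likewise gives > 50 ug/mL, also a limit. Compound 2 `COc1cc2c(cc1OC)CN(S(=O)(=O)c1ccc(-n3cc(COc4cc(C=O)ccc4OC)nn3)cc1)CC2` gives > 50 ug/mL, again a limit. All three thus sit on the same footing, (the limit of > 50 ug/mL in this assay, at which 3 of the 3 values shown sit). Compound 4 `COc1cc2c(cc1OC)CN(S(=O)(=O)c1ccc(-n3cc(COc4ccc(C=O)cc4OC)nn3)cc1)CC2` differs from compound 3 by 4-formyl-2-methoxyphenyl in place of hydrogen on an oxygen on a saturated carbon. Within the data shown here, the related steps a step that the two limits leave unreadable from compound 1 to compound 3 and a step that the two limits leave unreadable from compound 2 to compound 3 cannot be sized, and the step that the two limits leave unreadable from compound 1 to compound 2 is equally silent, so no measured step gives a readable size. The step is expected to be a number no higher from compound 3 to compound 4 (the limit leaves the size open), with no change beyond the scatter. Compound 4 is therefore estimated at 50 ug/mL, between 30 ug/mL and 100 ug/mL.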

Compound 4, half-maximal inhibitory concentration: > 50 ug/mL
Compound 4: only a limit was reported; the forecaster's own chance of this, stated with the estimate: 85%; the middle value lies on the limit itself.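

Compound 4 gives only a limit, as do compound 1, compound 2 and compound 3, so no new step among these four compounds can be read. The compounds shown leave open where each true value lies in this assay and whether the differing groups change it at all.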